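Adding 4-chlorobenzyl to compound 1

This account rests on a few compounds, and the source may have more. Where it says the series, first, only, none or still open, it means among the compounds named here.

Compound 1 `OC(c1cccs1)c1cc2ccccc2nc1Cl` gives 17500 nM
Compound 2 `FC(F)(F)c1cccc(COC(c2cccs2)c2cc3ccccc3nc2Cl)c1` gives "not active" (no number reported)

Going by the values given here, in a functional assay on HeLa cells (Homo sapiens) for inhibition, read by WST assay, with stated times of 72 h and 2 h (a lower number here means a stronger inhibitor, a higher number a weaker inhibitor), compound 1 gives 17500 nM as the only number available, while compound 2 is reported as "not active" (no number reported) and has no number. Among the compounds with values here, compound 1 therefore stands alone on the scale, with no measured step to set beside it.

The next compound to be tested is compound 3 `Clc1ccc(COC(c2cccs2)c2cc3ccccc3nc2Cl)cc1`, which differs from compound 1 at one place: 4-chlorobenzyl in place of hydrogen on an oxygen on a saturated carbon. Here 4-chlorobenzyl stands in place of hydrogen on an oxygen on a saturated carbon. Within the data shown here, no measured step shows what such a change does. The result for compound 2, "not active" (no number reported), offers no sign of a gain, so weaker inhibition is expected. The estimated shift is a 2.3-fold higher number from compound 1 to compound 3 (0.36 log units; beyond the scatter) in this direction, and a result with no number would not surprise. For compound 3 the expected value is 40000 nM, with an estimated range of 12000 nM to 100000 nM.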

Compound 3, half-maximal inhibitory concentration: "not active" (no number reported)
Nothing numeric was reported for compound 3; there is nothing to compare the estimate with.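

Going by these compounds alone, compound 3, like compound 2, is reported in this assay as not active, without a number, so no step from compound 1 can be read. The compounds shown leave open how large any change from adding 4-chlorobenzyl to compound 1 would be. No evidence bears on this result.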